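The compounds below may be only part of what the source reports. "The series", "measured", "known", "first", "only" and "open" are said of these compounds alone.

Measured compounds:
compound 1 `CN(C)C(=O)Nc1cccc(-c2ccc(N(C)C)cc2)c1` — 98%
compound 2 `COC(=O)Nc1cccc(-c2ccc(N(C)C)cc2)c1` — 95%
compound 3 `CN(C)c1ccc(-c2cccc(NC(=O)Oc3ccccc3)c2)cc1` — 75%

In an assay on COS-7 cells for inhibition of patatin-like phospholipase domain-containing protein 2 (Mus musculus), tested at 200 uM (on this read-out lower numbers stand for less inhibition and higher numbers for more inhibition at the one concentration tested (going by the name of the read-out)), compound 3 stands lowest of the three numbers. Its nearest neighbour is compound 2, from which it is reached by the step of a number 20 percentage points lower from compound 2 to compound 3 (beyond the scatter), and its furthest is compound 1, reached by the step of a number 23 percentage points lower from compound 1 to compound 3 (beyond the scatter). The step of a number 3 percentage points lower from compound 1 to compound 2 (within the scatter) between the two higher compounds stays within the scatter, so those two cannot be ordered.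

Compound 4 `CN(C)c1ccc(-c2cccc(NC(=O)C(C)(C)C)c2)cc1` differs from compound 3 by tert-butyl in place of phenoxy on a carbonyl carbon. The two steps that bear on this position are a number 23 percentage points lower from compound 1 to compound 3 (beyond the scatter) and a number 20 percentage points lower from compound 2 to compound 3 (beyond the scatter), both modest and both beyond the scatter; each of them arrives at the phenoxy group of compound 3 from a smaller group on the same carbonyl carbon, and each of them loses inhibition. Going back to a small group on that carbon is therefore expected to recover part of what compound 3 lost.

Compound 4 is expected to give about 88%, within a range from 72% to 99%. This estimate means a step of a number 13 percentage points higher from compound 3 to compound 4 (beyond the scatter), an expected rise of modest size, beyond the scatter but not certainly so.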

Compound 4, a percentage reported as inhibition, at one concentration (the size of the read-out at that concentration, not a potency): 25%
Estimate against measurement, compound 4: 63 percentage points above, and the stated range ends above it.
By their numbers in this assay, from the lowest: compound 4; then compound 3; then compounds 2 and 1 (each within the scatter of the next).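

In this assay, the step of a number 50 percentage points lower from compound 3 to compound 4 (beyond the scatter) shows that fewer heavy atoms on the carbonyl carbon do not by themselves restore inhibition, since tert-butyl is the smaller of the two groups by that count. Within the data shown here, the steps of a number 70 percentage points lower from compound 2 to compound 4 (beyond the scatter) and a number 73 percentage points lower from compound 1 to compound 4 (beyond the scatter) are also large, so methoxy, dimethylamino and phenoxy all stand clearly above tert-butyl, the only group among the four joined to the carbonyl carbon through carbon. Nothing available explains this loss.

From the compounds shown here alone, how a methyl or a tert-butoxy group on the same carbonyl carbon would stand remains open, and with it whether the drop follows the link through carbon or the branching of tert-butyl. With a single tested concentration, these numbers also leave the potency of all four compounds open.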